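A few compounds are considered here, and "the series" means these few. Any claim that something is new, unique, unknown or untested is made for them only; others in the source may bear on it.

Working notes on the series.

Within the data shown here, compound 1 `CN(C)CCn1cnnc1-c1cc(Oc2ccc(NC(=O)N/N=C/c3cccc(Cl)c3Cl)cc2F)ccn1` holds the lowest number of the two measured so far. In a functional assay on A549 cells (Homo sapiens) for cytotoxicity, read by MTT assay, with a stated time of 72 h (on this read-out lower numbers stand for stronger inhibition and higher numbers for weaker inhibition), compound 1 gives 1090 nM. Compound 2 `Cn1cnnc1-c1cc(Oc2ccc(NC(=O)N/N=C/c3ccccc3)cc2F)ccn1` differs from it in more than one place; in this assay compound 2 gives 7560 nM, a number that stands well beyond the scatter from that of compound 1, so compound 1 is the stronger inhibitor of the pair on the numbers at hand.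

Compound 3 `Cc1cc(/C=N/NC(=O)Nc2ccc(Oc3ccnc(-c4nncn4CCN(C)C)c3)c(F)c2)cc(C)c1O` is the next member to be read in this assay. It differs from compound 1 in one place: 4-hydroxy-3,5-dimethylphenyl in place of 2,3-dichlorophenyl on a carbon with a double bond to nitrogen. Among the measured compounds shown here, no measured pair in the set isolates a change of this kind, so nothing here fixes its size in this assay. The expectation is a modest step from compound 1 to compound 3 of a 1.5-fold higher number from compound 1 to compound 3 (0.17 log units; within the scatter), towards a somewhat higher number, though one that may well lie within the scatter. Compound 3 is accordingly estimated at 1600 nM, with a range from 500 nM to 5000 nM.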

Compound 3, half-maximal inhibitory concentration: 1640 nM
For compound 3 the middle estimate is 1.0-fold (0.01 log units) below the measured one; the range from low to high includes it.
By their numbers in this assay, from the lowest: compounds 1 and 3 (each within the scatter of the next); then compound 2.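

In this assay, among these compounds, the exchange of 2,3-dichlorophenyl for 4-hydroxy-3,5-dimethylphenyl on a carbon with a double bond to nitrogen gives a 1.5-fold higher number from compound 1 to compound 3 (0.18 log units; within the scatter) and is the first step that isolates one place. This place therefore accepts a quite different substituted phenyl, with a hydrogen-bond donor and acceptor now counted where the leaving group has none, and the outcome cannot be told apart from the scatter. No measured property is at hand to explain this step.

On these data alone, the hydroxy group and the two methyl groups enter together, so their separate contributions stay open. Also open, as far as these compounds go, is how this place responds to a 4-methoxyphenyl group or to a phenyl ring carrying an amine or a carboxylic acid.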